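This account rests on a few compounds, and the source may have more. Where it says the series, first, only, none or still open, it means among the compounds named here.

Three measured compounds share one core. Compound 1 `Cc1cc(/C=C/C#N)cc(C)c1Oc1ccnc(Nc2ccc(CN3CCCN(S(=O)(=O)C(C)C)CC3)cc2)n1` gives 4640 nM in an ADME assay on MT4 cells (Homo sapiens) for cytotoxicity, read by MTT assay; on this read-out higher numbers stand for lower toxicity in this test and lower numbers for higher toxicity in this test. Compound 2 `Cc1cc(/C=C/C#N)cc(C)c1Oc1ccnc(Nc2ccc(CN3CCN(S(=O)(=O)N(C)C)CC3)cc2)n1` gives 3070 nM in this assay, and compound 3 `CCS(=O)(=O)N1CCN(Cc2ccc(Nc3nccc(Oc4c(C)cc(C#N)cc4C)n3)cc2)CC1` gives 5240 nM. Compound 2 shows the smallest of the three numbers, but the numbers of compound 1 and compound 3 both lie within the usual scatter of it, so the three are not told apart in this assay.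

Compound 4 `Cc1cc(/C=C/C#N)cc(C)c1Oc1ccnc(Nc2ccc(CN3CCN(S(=O)(=O)C4CC4)CC3)cc2)n1` has not yet been measured. It differs from compound 2 by cyclopropyl in place of dimethylamino on a sulfonyl sulfur. Going by the values given here, no measured pair shows this change, so the step expected from compound 2 to compound 4 is a 1.1-fold higher number from compound 2 to compound 4 (0.06 log units; within the scatter), nothing beyond the scatter in either direction. Compound 4 is therefore estimated at 3500 nM, between 1500 nM and 8000 nM.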

Compound 4, half-maximal cytotoxic concentration: 4350 nM
Compound 4: the middle estimate sits 1.2-fold (0.09 log units) below what was measured; low and high end bracket the measured number.
By their numbers in this assay, from the lowest: compounds 2, 4, 1 and 3 (each within the scatter of the next).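

This is the first pair of compounds shown that differ in one place: on a sulfonyl sulfur, cyclopropyl in place of dimethylamino gives a 1.4-fold higher number from compound 2 to compound 4 (0.15 log units; within the scatter) in this assay. A ring of carbon only can therefore stand where dimethylamino stood, and the two compounds are not told apart in this test. Nothing measured here offers a reason for this result. As far as these compounds go, it remains open whether a longer chain, an amine or a carboxylic acid on this sulfonyl sulfur would also stay within the scatter of compound 2. From the compounds shown here alone, whether the same change would give a similar step on the core of compound 3 also remains open.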